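Aryl change from compound 2 to compound 3

A few compounds are considered here, and "the series" means these few. Any claim that something is new, unique, unknown or untested is made for them only; others in the source may bear on it.

Measured in a functional assay on SGC-7901 cells (Homo sapiens) for inhibition, read by MTT assay, with a stated time of 24 h; on this read-out higher numbers stand for weaker inhibition and lower numbers for stronger inhibition
- Compound 1 `CC1(C)[C@H]2CC[C@]1(C)N(Cc1cn(-c3ccc(C#N)cc3)nn1)C(=O)C2` gives 500 nM
- Compound 2 `Cc1ccc(-n2cc(CN3C(=O)C[C@@H]4CC[C@@]3(C)C4(C)C)nn2)cc1` gives 390 nM

In this assay compound 2 stands at 390 nM and lies within the scatter of compound 1, so these two numbers give no ranking. Compound 3 `CC1(C)[C@H]2CC[C@]1(C)N(Cc1cn(-c3cccc(Br)c3)nn1)C(=O)C2` differs from compound 2 by 3-bromophenyl in place of 4-methylphenyl on an aromatic nitrogen with 3-bromophenyl in place of 4-methylphenyl on an aromatic nitrogen. Going by the values given here, the only measured step bearing on this change is a 1.3-fold lower number from compound 1 to compound 2 (0.11 log units; within the scatter) for methyl in place of cyano on an aromatic carbon, which gives no ground to expect a shift beyond the scatter. Among the compounds with values here, no measured compound carries 3-bromophenyl, so the evidence is thin. The expected size is a 1.0-fold higher number from compound 2 to compound 3 (0.01 log units; within the scatter) with no direction favoured. For compound 3 the estimated value is 400 nM with an expected range of 170 nM to 950 nM around it.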

Compound 3, half-maximal inhibitory concentration: 120 nM
Compound 3: middle estimate off by 3.3-fold (0.52 log units), on the high side; the measured number lies below the stated range.
By their numbers in this assay, from the lowest: compound 3; then compounds 2 and 1 (each within the scatter of the next).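

Replacing the 4-substituted phenyl on the aromatic nitrogen with 3-bromophenyl moves the number in this assay beyond the scatter, which the swap of methyl for cyano did not do: 3-bromophenyl in place of 4-methylphenyl gives a 3.3-fold lower number from compound 2 to compound 3 (0.51 log units; beyond the scatter), and 3-bromophenyl in place of 4-cyanophenyl gives a 4.2-fold lower number from compound 1 to compound 3 (0.62 log units; beyond the scatter). Both steps change the substituent and its place on the phenyl ring together, so the effect of bromine cannot be separated from the effect of its place. No supporting measurement accounts for the gain.

Open, on these data alone, is whether 4-bromophenyl would keep the gain, or whether 3-methylphenyl and 3-cyanophenyl would share it. Also open, as far as these compounds go, is how a 3-aminophenyl or 3-carboxyphenyl group would read at this position.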